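Replacing trifluoromethyl with acetamido on compound 3

The compounds below may be only part of what the source reports. "The series", "measured", "known", "first", "only" and "open" are said of these compounds alone.

In a functional assay on HL-60 cells (Homo sapiens) for inhibition, read by MTT assay, with a stated time of 72 h (on this read-out lower numbers stand for stronger inhibition and higher numbers for weaker inhibition), compound 1 `CCOc1cccc(N2CCN(C(=O)c3oc(C)nc3-c3ccccc3)CC2)c1` gives 151 nM, compound 2 `Cc1cc(C)cc(N2CCN(C(=O)c3oc(C)nc3-c3ccccc3)CC2)c1` gives 34.5 nM and compound 3 `Cc1nc(-c2ccccc2)c(C(=O)N2CCN(c3cccc(C(F)(F)F)c3)CC2)o1` gives 153 nM. Compound 3 therefore matches compound 1 within the scatter, and both show weaker inhibition than compound 2. Compound 4 `CC(=O)Nc1cccc(N2CCN(C(=O)c3oc(C)nc3-c3ccccc3)CC2)c1` has acetamido in place of trifluoromethyl on an aromatic carbon. The closest guide is a swap of one group on the same kind of carbon, a 1.0-fold higher number from compound 1 to compound 3 (0.01 log units; within the scatter). The other relevant step, a 4.4-fold higher number from compound 2 to compound 3 (0.65 log units; beyond the scatter), replaces 3,5-dimethylphenyl. Among the measured compounds shown here, no measured compound carries acetamido, so the expectation is uncertain, and no step beyond the scatter is expected in this assay. The expected change is a 1.1-fold higher number from compound 3 to compound 4 (0.05 log units; within the scatter). Compound 4 is estimated at 170 nM, with an expected range of 50 nM to 600 nM.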

Compound 4, half-maximal inhibitory concentration: 329 nM
For compound 4 the middle estimate is 1.9-fold (0.29 log units) below the measured one, within the range that was stated.
By their numbers in this assay, from the lowest: compound 2; then compounds 1 and 3 (each within the scatter of the next); then compound 4.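

In this assay, this position proves sensitive to the group it carries: ethoxy and trifluoromethyl had matched within the scatter, but acetamido separates from both (a 2.2-fold higher number from compound 3 to compound 4 (0.33 log units; beyond the scatter) and a 2.2-fold higher number from compound 1 to compound 4 (0.34 log units; beyond the scatter)). The step from the 3,5-dimethylphenyl compound is larger (a 9.5-fold higher number from compound 2 to compound 4 (0.98 log units; beyond the scatter)). No measurement here accounts for the change in number. The compounds shown leave open whether an amine or a carboxylic acid on this aromatic carbon would behave like acetamido. They also leave open whether a methyl group on the amide nitrogen would alter the number.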